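Removing a Methoxy Group: Does Anything Change?

The source may report more compounds than this note shows. Statements on the series, on what has been measured and on what is new or still open speak of the compounds shown alone.

Of the compounds shown here, three have so far been measured in a functional assay on Hep 3B2 cells (Homo sapiens) for antiproliferative activity, read by MTT assay, with a stated time of 24 h, tested at 0.05 ug/mL; on this read-out lower numbers stand for a weaker effect and higher numbers for a stronger effect at the one concentration tested. Compound 1 `Cc1c(C(=O)Nc2c(F)cc(-c3cccc(F)c3)cc2F)nc2ccc(F)cc2c1O` gives 1.25%, compound 2 `CCOc1ccc2nc(C(=O)Nc3c(F)cc(-c4cccc(F)c4)cc3F)c(C)c(O)c2c1` gives -0.04%, and compound 3 `COc1ccc2nc(C(=O)Nc3ccc(-c4ccccc4)cc3)c(C)c(O)c2c1` gives 1.23%. All three numbers lie within the scatter of one another, so compound 3 stands among them without real distinction, and none of the three can be called stronger or weaker. For the measured compounds named here, the only measured step, a number 1.3 percentage points lower from compound 1 to compound 2 (within the scatter), shows that swapping one group on an aromatic carbon of the shared core left the read-out essentially unmoved. Compound 4 `Cc1c(C(=O)Nc2ccc(-c3ccccc3)cc2)nc2ccccc2c1O` differs from compound 3 by hydrogen in place of methoxy on an aromatic carbon. Going by the values given here, no measured step removes a group entirely, but the single comparable change stayed within the scatter, so the expected step is a number 0.2 percentage points lower from compound 3 to compound 4 (within the scatter). Compound 4 is therefore estimated to give 1%, ranging from -8% to 10%.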

Compound 4, a percentage reported as inhibition, at one concentration (the size of the read-out at that concentration, not a potency): 1.68%
The estimate for compound 4 lay 0.7 percentage points below the measured number, and the stated range covers the measured number.
By their numbers in this assay, from the lowest: compounds 2, 3, 1 and 4 (each within the scatter of the next).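

In this assay, taking the methoxy group away and leaving only hydrogen gives a number 0.5 percentage points higher from compound 3 to compound 4 (within the scatter) and so does not separate the two compounds. The earlier step exchanged one group for another on this kind of aromatic carbon, whereas this one shows that having no group there also stays within the scatter. Nothing available explains why the read-out stays flat here.

From the compounds shown here alone, what an amine or a carboxylic acid on this aromatic carbon would do remains open. So does whether a longer chain in place of the methyl group on the shared core would move the read-out.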